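This account rests on a few compounds, and the source may have more. Where it says the series, first, only, none or still open, it means among the compounds named here.

Compound 2 `Cc1ccc(S(=O)(=O)Nc2ccc(CNC(=O)CC3c4ccccc4N=C(N4CCCCC4)N3c3ccccc3)cc2)cc1` gives 89.9% in a functional assay on HEK293 cells for inhibition of Voltage-dependent T-type calcium channel subunit alpha-1G (Homo sapiens), tested at 10 uM (on this read-out lower numbers stand for less inhibition and higher numbers for more inhibition at the one concentration tested (going by the name of the read-out)), and stands next to compound 1 `O=C(CC1c2ccccc2N=C(N2CCCCC2)N1c1ccccc1)NCc1ccccc1`, which gives 90.1% in this assay; the step of a number 0.2 percentage points lower from compound 1 to compound 2 (within the scatter) is within the scatter. Compound 3 `O=C(CC1c2ccccc2N=C(N2CCCCC2)N1c1ccccc1)NCc1ccc(NS(=O)(=O)c2ccc(F)cc2)cc1` differs from compound 2 by fluoro in place of methyl on an aromatic carbon. Among the compounds with values here, no measured step involves the 4-methylphenyl part of the ((4-methylphenyl)sulfonyl)amino group, so the only available comparison is the step from compound 1 to compound 2, which stays within the scatter with the whole group added. On that basis no step beyond the scatter is expected in this assay, and the expected step is a number 0.9 percentage points lower from compound 2 to compound 3 (within the scatter). Compound 3 is estimated at 89%, with a range from 78% to 96%.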

Compound 3, a percentage reported as inhibition, at one concentration (the size of the read-out at that concentration, not a potency): 89%
For compound 3 middle estimate and measured number coincide at the digits printed, within the range that was stated.
By their numbers in this assay, from the lowest: compounds 3, 2 and 1 (each within the scatter of the next).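

Fluoro in place of methyl gives a number 0.9 percentage points lower from compound 2 to compound 3 (within the scatter) in this assay, so this change at the far end of the added group leaves the number within the scatter. Added whole, the ((4-fluorophenyl)sulfonyl)amino group gives a number 1.1 percentage points lower from compound 1 to compound 3 (within the scatter), matching what the ((4-methylphenyl)sulfonyl)amino group showed. No measurement on hand accounts for this flat reading.

From the compounds shown here alone, whether an amine or a carboxylic acid in place of fluoro would hold the number remains open. A single-concentration read-out also leaves any potency differences among these compounds open.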